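The source may hold more compounds than are shown below. What is called first, only, known or untested is meant among the compounds shown, and "the series" means these compounds.

Measured in an assay on HEK293 cells for positive allosteric modulation of metabotropic glutamate receptor 3 (Rattus norvegicus), read by thallium flux, with a stated time of 2.5 min; on this read-out lower numbers stand for an effect already at smaller amounts and higher numbers for an effect only at larger amounts of compound:

compound 1 `Cc1c(OCCCCOc2ccc(F)c(C(=O)O)c2)ccc(C(=O)CC2CCCC2)c1O` gives 2490 nM.
compound 2 `Cc1cc(C(=O)O)ccc1OCCCCOc1ccc(C(=O)CC2CCCC2)c(O)c1C` gives > 10000 nM; this is a limit of the assay, not a number.
compound 3 `Cc1c(OCCCCOc2cccc(C(=O)O)c2)ccc(C(=O)CC2CCCC2)c1O` gives 3400 nM.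

Compound 1 holds the lowest of the two numbers; compound 3 is its nearest neighbour, and the step of a 1.4-fold higher number from compound 1 to compound 3 (0.14 log units; within the scatter) lies within the scatter. Compound 2 sits at the limit (the limit of > 10000 nM in this assay, at which 1 of the 3 values shown sits).

Compound 4 `Cc1c(OCCCCOc2ccc(F)c(C(=O)O)c2)ccc(C(=O)C(C)C)c1O` is not yet measured. It differs from compound 1 at the carbonyl carbon: isopropyl in place of cyclopentylmethyl on a carbonyl carbon.

Every measured step concerns the other end of the chain, the aryl carboxylic acid: an at least 4.0-fold higher number from compound 1 to compound 2 (0.60 log units; beyond the scatter), an at least 2.9-fold lower number from compound 2 to compound 3 (0.46 log units; beyond the scatter) and a 1.4-fold higher number from compound 1 to compound 3 (0.14 log units; within the scatter). For the measured compounds named here, no measured pair changes the group on the carbonyl carbon, so no step bears directly on the move to compound 4. With no guidance either way, the expectation is a change no larger than the scatter, leaning to a somewhat higher number: for compound 4 the expected result in this assay is 3500 nM, with a range from 1200 nM to 10000 nM. The step this estimate implies, a 1.4-fold higher number from compound 1 to compound 4 (0.15 log units; within the scatter), is expected to stay close to the scatter.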

Compound 4, half-maximal effective concentration: > 10000 nM
Compound 4 was reported as a limit; the forecaster's own chance of this, stated with the estimate: 20%; middle value at least 2.8-fold (0.45 log units) from the limit.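

The group on the carbonyl carbon matters in this assay: with the aryl carboxylic acid end unchanged, the exchange gives an at least 4.0-fold higher number from compound 1 to compound 4 (0.60 log units; beyond the scatter). This is the first step shown at this end of the molecule, and it shows that the position does not tolerate every replacement of cyclopentylmethyl, with its five-membered ring and 6 heavy atoms, by a group without a ring, here isopropyl with 3 heavy atoms. The result for compound 4 is a limit of the assay and not a number: the limit of > 10000 nM in this assay, at which 2 of the 4 values shown sit.

From the compounds shown here alone, whether the loss follows the ring or the count of heavy atoms stays open, and a cyclohexylmethyl group or a longer straight chain on the carbonyl carbon would separate the two. Also open, going by these compounds, is whether the same exchange reads alike with the 3-carboxyphenyl end of compound 3.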